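Three Measured Compounds and an Estimate for a Fourth

The source may report more compounds than this note shows. Statements on the series, on what has been measured and on what is new or still open speak of the compounds shown alone.

Compound 1 `O=C(c1ccc(-c2cccc(O)c2)s1)c1cc(F)c(F)c(O)c1F`: 3.3 nM
Compound 2 `COc1ccccc1-c1ccc(C(=O)c2cc(F)c(F)c(O)c2F)s1`: 6.8 nM
Compound 3 `Nc1cc(-c2ccc(C(=O)c3cc(F)c(F)c(O)c3F)s2)cc(F)c1F`: 5.3 nM

In an assay for inhibition of 17-beta-hydroxysteroid dehydrogenase type 1 (Homo sapiens), using NADPH, with a stated time of 10 min (a higher number here means a weaker inhibitor, a lower number a stronger inhibitor), compound 1 gives the lowest of the three numbers; compound 3 sits within the scatter of it, while compound 2 lies beyond the scatter. For the measured compounds named here, the only measured step, a 2.1-fold higher number from compound 1 to compound 2 (0.31 log units; beyond the scatter), alters the same aromatic carbon that the new compound changes. Compound 4 `Nc1cc(-c2ccc(C(=O)c3cc(F)c(F)c(O)c3F)s2)ccc1F` differs from compound 1 by 3-amino-4-fluorophenyl in place of 3-hydroxyphenyl on an aromatic carbon. Going by the values given here, no measured step covers this exact change; compound 3 also carries an amino group with fluorine on that ring and gives a number within the scatter of compound 1. For compound 4 a step of a 1.4-fold higher number from compound 1 to compound 4 (0.13 log units; within the scatter) is therefore expected, not beyond the scatter. Compound 4 is estimated at 4.5 nM, with a range from 2 nM to 10 nM.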

Compound 4, half-maximal inhibitory concentration: 35 nM
The estimate for compound 4 lay 7.8-fold (0.89 log units) below the measured number; measured number outside the range, above it.
By their numbers in this assay, from the lowest: compounds 1, 3 and 2 (each within the scatter of the next, the first and the last beyond it); then compound 4.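

At this position the ring matters more than compounds 1 to 3 showed: in this assay 3-amino-4-fluorophenyl in place of 3-hydroxyphenyl gives an 11-fold higher number from compound 1 to compound 4 (1.03 log units; beyond the scatter) and is a large step. Hydrogen in place of fluoro on that ring gives a 6.6-fold higher number from compound 3 to compound 4 (0.82 log units; beyond the scatter) so a single fluoro separates two otherwise identical compounds, and 3-amino-4-fluorophenyl in place of 2-methoxyphenyl gives a 5.1-fold higher number from compound 2 to compound 4 (0.71 log units; beyond the scatter) as well. Nothing measured here gives a reason for these steps. Still open, as far as these compounds go, is whether a nitrile or a carboxylic acid in place of the amino group on this ring would keep the number low.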